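A few compounds are considered here, and "the series" means these few. Any claim that something is new, unique, unknown or untested is made for them only; others in the source may bear on it.

Measured in a functional assay on thoracic aorta (Rattus norvegicus, strain Wistar), with a stated time of 15 min; a lower number here means that less compound is needed, a higher number that more compound is needed for the effect:
- Compound 1 `CC(NC(=O)NS(=O)(=O)c1ccc(Cl)cc1)c1ccccc1OCc1ccccc1`: 157000 nM
- Compound 2 `Cc1ccc(S(=O)(=O)NC(=O)NC(C)c2ccccc2OCc2ccccc2)cc1`: > 200000 nM, a limit
- Compound 3 `CC(NC(=O)NS(=O)(=O)c1ccccc1)c1ccccc1OCc1ccccc1`: > 200000 nM, a limit

Compound 2 gives no number and stands at the limit of > 200000 nM in this assay, at which 2 of the 3 values shown sit. The change to compound 4 `Cc1ccc(S(=O)(=O)N(C)C(=O)NC(C)c2ccccc2OCc2ccccc2)cc1` is methyl in place of hydrogen on an amide-type nitrogen.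

Among the compounds with values here, all the measured steps lie on an aromatic carbon: an at least 1.2-fold higher number from compound 1 to compound 2 (0.10 log units; that floor lies within the scatter) for methyl in place of chloro, an at least 1.2-fold higher number from compound 1 to compound 3 (0.10 log units; that floor lies within the scatter) for hydrogen in place of chloro, and a step that the two limits leave unreadable from compound 2 to compound 3 for hydrogen in place of methyl. None of them touches this nitrogen, and none offers a size or direction to carry over. In this assay, no step beyond the scatter is therefore expected, and no direction can be given. The expected outcome is a number no higher from compound 2 to compound 4 (the limit leaves the size open). Compound 4 is estimated at 200000 nM, with an expected range from 60000 nM to 400000 nM, and a report as a limit alone is likely.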

Compound 4, half-maximal effective concentration: 31000 nM
Compound 4: middle estimate off by 6.5-fold (0.81 log units), on the high side; measured number below the stated range.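

In this assay, the amide-type nitrogen whose other neighbours are the carbonyl carbon and the sulfonyl sulfur is the only position in this series with a readable step beyond the scatter: methyl in place of hydrogen gives an at least 6.4-fold lower number from compound 2 to compound 4 (0.80 log units; beyond the scatter) and so marks this nitrogen as a place where the series responds. The earlier steps shown here, all on an aromatic carbon, gave only floors within the scatter or could not be read. As far as these compounds go, the full size of the new step stays open, since its starting point is a limit and not a number: the limit of > 200000 nM in this assay, at which 2 of the 4 values shown sit.

From the compounds shown here alone, whether methyl at this nitrogen gives a similar step on compound 1 or compound 3 remains open. The compounds shown also do not tell whether a longer chain, such as ethyl, or a carboxylic acid at this nitrogen would keep the step.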